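A few compounds are considered here, and "the series" means these few. Any claim that something is new, unique, unknown or untested is made for them only; others in the source may bear on it.

Of the compounds shown here, three built on one shared core have been measured for how well they survive exposure to liver enzymes. In an ADME assay on microsomes from liver (Mus musculus) for metabolic stability, read by LC-MS, with a stated time of 10 min (on this read-out higher numbers stand for a more stable compound and lower numbers for a less stable compound), compound 3 `CN(C[C@H]1Cc2c(cccc2N2C[C@@H]3C[C@H]2CN3)CN1)[C@H]1CCCc2cccnc21` gives 36.3%, the lowest of the three numbers. Its nearest neighbour is compound 1 `CN(C[C@H]1Cc2c(cccc2N2CCN(Cc3ccccn3)CC2)CN1)[C@H]1CCCc2cccnc21`, which in this assay gives 40.4%, a number that lies within the usual scatter of compound 3, so the two cannot be told apart. Furthest away is compound 2 `c1cnc2c(c1)CCC[C@@H]2N(CC1CC1)C[C@H]1Cc2c(cccc2N2CCNCC2)CN1`, which in this assay gives 88.3%, a number that lies well beyond the scatter above compound 3.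

Compound 4 `C[C@@H]1CN(c2cccc3c2C[C@H](CN(C)[C@H]2CCCc4cccnc42)NC3)C[C@H](C)N1C` differs from compound 3 in one place: a group of 9 heavy atoms (7 carbon, 2 nitrogen; one six-membered non-aromatic ring with 2 hetero atoms) in place of a group of 7 heavy atoms (5 carbon, 2 nitrogen; 2 five-membered non-aromatic rings with 1 hetero atom each), on an aromatic carbon. Within the data shown here, no pair of measured compounds differs in only one place, so no measured step can guide this change directly. The numbers seen so far span from low to high, and compound 4 is expected to land in the middle of that span, a step of a number 8.7 percentage points higher from compound 3 to compound 4 (within the scatter) that is estimated as small and upward. Compound 4 is therefore estimated to give 45% in this assay, with a likely range from 20% to 75%.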

Compound 4, percent of the compound remaining: 39.6%
Compound 4: middle estimate off by 5.4 percentage points, on the high side; the measured number falls inside the stated range.
By their numbers in this assay, from the lowest: compounds 3, 4 and 1 (each within the scatter of the next); then compound 2.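

Replacing the group with two five-membered non-aromatic rings by 3,4,5-trimethylpiperazin-1-yl on this aromatic carbon gives, in this assay, a number 3.3 percentage points higher from compound 3 to compound 4 (within the scatter), a step that stays within the usual scatter. Among these compounds, at this position, then, a change of ring type that also takes away a hydrogen-bond donor leaves the read-out indistinguishable, and this is the first direct one-place comparison. Nothing available accounts for this outcome, so the result stands as an observation only.

This single pair leaves open whether any group on this aromatic carbon can move the number beyond the scatter. A morpholine ring or a small dimethylamino group in the same place would test how far this tolerance extends.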